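Swapping a Saturated Ring for an Aromatic One

A few compounds are considered here, and "the series" means these few. Any claim that something is new, unique, unknown or untested is made for them only; others in the source may bear on it.

Compound 1 `Cc1cc(-c2cnn3c(NCC4CCOCC4)nc(NC4CCOCC4)nc23)ccc1C(=O)NC1CC1` is built on a shared core that carries two amine substituents, both bearing an oxane ring, and an amide-linked cyclopropyl group on its outer ring. In a functional assay on HCT-116 cells (Homo sapiens) for antiproliferative activity (a higher number here means a weaker inhibitor of growth, a lower number a stronger inhibitor of growth), compound 1 gives 280 nM. Compound 3 `O=C(NC1CC1)c1ccc(-c2cnn3c(NCC4CCOCC4)nc(NC4CCCC4)nc23)cc1F` gives 850 nM in this assay, and for compound 2 `Cc1cc(-c2cnn3c(NCC4CCOCC4)nc(NC4CCCC4)nc23)ccc1NC(=O)C1CC1` the entry there reads "not determined" (no result reported), so no result is reported for it. Among the two numbers available, compound 1 has the lower one, and the gap to compound 3 lies beyond the usual scatter of this measurement.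

Compound 4 `Cc1cc(-c2cnn3c(NCC4CCOCC4)nc(Nc4cccc(F)c4)nc23)ccc1C(=O)NC1CC1` differs from compound 1 only in one amine substituent: 3-fluorophenyl in place of oxan-4-yl on a nitrogen on an aromatic ring. Among the measured compounds shown here, no measured pair of compounds shows this particular exchange, so there is no directly comparable step to lean on. The expectation for compound 4 is a modest step toward a weaker inhibitor, though a result within the scatter of compound 1 cannot be excluded; in this assay compound 4 is estimated at 450 nM, with a plausible range from 130 nM to 1600 nM. This expectation corresponds to a step of a 1.6-fold higher number from compound 1 to compound 4 (0.21 log units; within the scatter).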

Compound 4, concentration for 50% growth inhibition: 9 nM
Compound 4: middle estimate off by 50-fold (1.70 log units), on the high side; the whole stated range lies above it.
By their numbers in this assay, from the lowest: compound 4; then compound 1; then compound 3.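

In this assay, putting 3-fluorophenyl in place of oxan-4-yl on this nitrogen gives a 31-fold lower number from compound 1 to compound 4 (1.49 log units; beyond the scatter), a large step well beyond the scatter. This shows that growth inhibition in these cells responds strongly to the group at this one position, with the rest of the molecule unchanged. The earlier compounds could not show this, as they offered no measured pair differing in one place, and nothing among the data given explains why the step is so large.

Going by these compounds, whether the stronger inhibition comes from the aromatic ring itself or from its fluorine stays open, and plain phenyl on the same nitrogen would separate the two. Also open, on these data alone, is how a pyridinyl ring, with nitrogen in the aromatic ring, would compare at this position.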